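A few compounds are considered here, and "the series" means these few. Any claim that something is new, unique, unknown or untested is made for them only; others in the source may bear on it.

Measured so far in a functional assay on CHO-K1 cells for antagonist activity at adenosine receptor A1 (Homo sapiens), read by a beta-galactosidase reporter and cAMP accumulation, with stated times of 15 min and 6 h; on this read-out lower numbers stand for stronger inhibition and higher numbers for weaker inhibition:
- compound 1, `Cc1ccc(-c2nc(N)c3cc(-c4ccccc4)sc3n2)o1`: 520 nM
- compound 2, `COc1ccccc1Cc1cc2c(N)nc(-c3ccc(C)o3)nc2s1`: 122 nM
- compound 3, `CCc1ccc(-c2nc(N)c3cc(Cc4ccccc4)sc3n2)o1`: 223 nM

Compound 3 holds the second highest of the three numbers. Its nearest neighbour is compound 2, whose number lies within the scatter of that of compound 3, so no order between the two can be read. Compound 1 gives the highest number, and the gap to compound 3 lies beyond the scatter.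

Compound 4, `Cc1nc(-c2nc(N)c3cc(Cc4ccccc4)sc3n2)cs1`, differs from compound 3 in one place: 2-methyl-1,3-thiazol-4-yl in place of 5-ethylfuran-2-yl on an aromatic carbon. Within the data shown here, no measured pair shows this change, so nothing sets its size. The expected step of a 1.6-fold higher number from compound 3 to compound 4 (0.20 log units; within the scatter) is small, toward a slightly higher number in this assay, not clearly beyond the scatter. For compound 4 the estimate is 350 nM, with a range from 120 nM to 1000 nM.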

Compound 4, inhibition constant: 263 nM
Estimate against measurement, compound 4: 1.3-fold (0.12 log units) above; the measured number falls inside the stated range.
By their numbers in this assay, from the lowest: compounds 2, 3, 4 and 1 (each within the scatter of the next, the first and the last beyond it).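

In this assay, among these compounds, 2-methyl-1,3-thiazol-4-yl in place of 5-ethylfuran-2-yl on the aromatic carbon between two ring nitrogen atoms gives a 1.2-fold higher number from compound 3 to compound 4 (0.07 log units; within the scatter), the first single-place step. This position therefore accepts either five-membered aromatic ring with no readable change, in this one pair only. No evidence on hand bears on this result.

On these data alone, whether an amine or a carboxylic acid on this carbon would keep the number remains open. Also open, as far as these compounds go, is whether the same change gives a similar step on the cores of compound 1 and compound 2.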